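Benzylsulfanyl series: chloro position on the benzyl ring

The source may report more compounds than this note shows. Statements on the series, on what has been measured and on what is new or still open speak of the compounds shown alone.

Measured so far:
compound 1, `COc1ccc(C2N=C(SCc3ccccc3)NC(C)=C2C(=O)Nc2ccc(F)cc2)cc1OC` — 6.2%
compound 2, `COc1ccc(C2N=C(SCc3ccccc3Cl)NC(C)=C2C(=O)Nc2ccc(F)cc2)cc1OC` — 11.8%

In a functional assay on the whole organism (artery, strain albino) with Rattus norvegicus as the target, with a stated time of 60 min, at a dose of 10 mg/kg by the oral route (a higher number here means more inhibition at the dose given (going by the name of the read-out), a lower number less inhibition), compound 1 gives 6.2% and compound 2 gives 11.8%. Only these two numbers exist in this assay, and they lie within the scatter of each other: the step of a number 5.6 percentage points higher from compound 1 to compound 2 (within the scatter) does not separate compound 2 from compound 1, so compound 2 stands alongside compound 1 rather than apart from it.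

Compound 3 is `COc1ccc(C2N=C(SCc3cccc(Cl)c3)NC(C)=C2C(=O)Nc2ccc(F)cc2)cc1OC`. Its difference from compound 2: 3-chlorophenyl in place of 2-chlorophenyl on a saturated chain carbon bound to a sulfur

Going by the values given here, the one measured step, a number 5.6 percentage points higher from compound 1 to compound 2 (within the scatter), concerns chloro in place of hydrogen and not a change in where the chloro sits, so it bears on the present step only loosely; it shows that adding the chloro did not move the number beyond the scatter. Among the compounds with values here, no measured pair tells how shifting the chloro from one position to another on the benzyl ring acts in this assay.

On that basis no step beyond the scatter is expected for compound 3, and the estimated step is a number 1.8 percentage points lower from compound 2 to compound 3 (within the scatter). Compound 3 is therefore expected to give about 10%, within 2% to 22%.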

Compound 3, a percentage reported as inhibition, in the whole organism at one dose (the size of the read-out at that dose, not a potency): 8.2%
Estimate against measurement, compound 3: 1.8 percentage points above, within the range that was stated.
By their numbers in this assay, from the lowest: compounds 1, 3 and 2 (each within the scatter of the next).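

In this assay, going by these compounds alone, the step from 2-chlorobenzyl to 3-chlorobenzyl on the sulfur gives a number 3.6 percentage points lower from compound 2 to compound 3 (within the scatter), the first measured comparison of where the chloro sits on this ring, and it does not separate the two chloro placements. Set against the unsubstituted benzyl group, the 3-chlorophenyl variant gives a number 2 percentage points higher from compound 1 to compound 3 (within the scatter), so, together with a number 5.6 percentage points higher from compound 1 to compound 2 (within the scatter), neither chloro placement stands apart from the benzyl group without chloro in this small set. No measurement at hand offers an explanation for these numbers.

As far as these compounds go, whether a benzyl ring carrying an amine or a carboxylic acid, or a longer chain in place of the benzyl group, would give a number beyond the scatter from these three compounds remains open. The readings also come from a single oral dose and a single stated time, so they leave open whether the three compounds would still stand together at another dose or at another time.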